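The source may hold more compounds than are shown below. What is called first, only, known or untested is meant among the compounds shown, and "the series" means these compounds.

Among the measured compounds shown here, in a functional assay on BXPC-3 cells (Homo sapiens) for antiproliferative activity, read by sulforhodamine B assay, with a stated time of 72 h (on this read-out higher numbers stand for weaker inhibition and lower numbers for stronger inhibition), compound 1 `CC(C)(C)c1[nH]cnc1/C=c1\[nH]c(=O)/c(=C/c2cccc(C(=O)N3CCCC3)c2)[nH]c1=O` gives 325 nM, the only exact number available so far. Compound 2 `O=C(c1cccc(/C=c2\[nH]c(=O)/c(=C/c3ccccn3)[nH]c2=O)c1)N1CCCCC1` is recorded at > 500 nM, which is a limit of the assay and not a number. That leaves compound 1 as the single firm reference point, with no measured series around it.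

Compound 3 `CC(C)(C)c1[nH]cnc1/C=c1\[nH]c(=O)/c(=C/c2cccc(C(=O)c3ccncc3)c2)[nH]c1=O` keeps the core of compound 1 and alters one group, with pyridin-4-yl in place of pyrrolidin-1-yl on a carbonyl carbon. The same difference can be read as (pyrrolidin-1-yl)carbonyl turning into (pyridin-4-yl)carbonyl.

For the measured compounds named here, no two measured compounds differ in just one place, so the data do not show directly what a swap of this kind does in this assay. The expectation is therefore tentative and starts from compound 1 at 325 nM. The expected change, a 2.5-fold lower number from compound 1 to compound 3 (0.40 log units; beyond the scatter), is a moderate one toward stronger inhibition, with a return to weaker inhibition still quite possible. For compound 3 the estimated value is 130 nM, with an expected range from 25 nM to 500 nM.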

Compound 3, half-maximal inhibitory concentration: 23.8 nM
Compound 3: the middle estimate sits 5.5-fold (0.74 log units) above what was measured; measured number outside the range, below it.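

Among the compounds shown here, putting pyridin-4-yl in place of pyrrolidin-1-yl on a carbonyl carbon gives a 14-fold lower number from compound 1 to compound 3 (1.14 log units; beyond the scatter) in this assay, and this is the only single change that can be read so far. It shows that the group on this carbonyl carbon can strongly shift the read-out, and that the pyrrolidin-1-yl group is not required for activity here. The step changes several things at once, since a five-membered non-aromatic ring leaves, a six-membered aromatic ring with a hydrogen-bond acceptor enters, and nothing measured here explains the lower number or assigns it to any one of these differences.

From the compounds shown here alone, it remains open whether the ring nitrogen matters or the aromatic ring alone is enough, a question that a plain phenyl group on the same carbonyl carbon would address, and pyridin-3-yl would test whether the place of that nitrogen in the ring counts. Also open, going by these compounds, is how far this position tolerates other kinds of group, such as a morpholin-4-yl ring, a simple amine or a carboxylic acid.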